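Chloro for Methyl: Expecting Compound 4 in Cytotoxicity

The compounds below may be only part of what the source reports. "The series", "measured", "known", "first", "only" and "open" are said of these compounds alone.

Compound 1 `N#Cc1c(N)cccc1Sc1cc(Cl)cc(Cl)c1`: 3000 nM in a functional assay on MT4 cells (Homo sapiens) for cytotoxicity; a lower number here means a stronger inhibitor, a higher number a weaker inhibitor
Compound 2 `Cc1cc(Cl)cc(Sc2cccc(N)c2C#N)c1`: 16000 nM
Compound 3 `Cc1ccc(S(=O)(=O)c2cccc(N)c2C#N)cc1`: this value is only a limit of the assay, > 200000 nM

Compound 2 and compound 1 differ by chloro in place of methyl on an aromatic carbon, and that step gave a 5.3-fold lower number from compound 2 to compound 1 (0.73 log units; beyond the scatter). Compound 4 `N#Cc1c(N)cccc1S(=O)(=O)c1ccc(Cl)cc1` has not yet been measured in this assay. It differs from compound 3 by chloro in place of methyl on an aromatic carbon, the same kind of change, though here the place is para to a large group rather than meta to a chloro group and meta to a large group. The difference between the cores of compound 2 and compound 3 is not broken down here. Because compound 3 sits at the limit of > 200000 nM in this assay, at which 1 of the 3 values shown sits, its starting number is not known. Compound 4 is expected to give 150000 nM, between 40000 nM and 300000 nM. The expected step of an at least 1.3-fold lower number from compound 3 to compound 4 (0.12 log units; that floor lies within the scatter) rests on the measured step of a 5.3-fold lower number from compound 2 to compound 1 (0.73 log units; beyond the scatter) of the same kind of change.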

Compound 4, half-maximal inhibitory concentration: > 5000 nM
Compound 4 gave a limit, no number; the forecaster's own chance of this, stated with the estimate: 60%; the middle value is on the limit's open side.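

Compound 3 and compound 4 both gave only limits in this assay, and the step between them cannot be read. The compounds shown leave open whether chloro in place of methyl on an aromatic carbon changes the number on the core of compound 3.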